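The source may report more compounds than this note shows. Statements on the series, on what has been measured and on what is new or still open speak of the compounds shown alone.

In a functional assay on MKN-45 cells (Homo sapiens) for cytotoxicity (on this read-out lower numbers stand for stronger inhibition and higher numbers for weaker inhibition), compound 3 `COc1ccc(S(=O)(=O)N2CCc3cccc(NC(=O)c4ccccc4)c32)cc1` gives 250 nM. Compound 1 `COC(=O)c1ccc(C(=O)Nc2cccc3c2N(S(=O)(=O)c2ccc(OC)cc2)CC3)cc1` gives 312 nM, and a 1.2-fold lower number from compound 1 to compound 3 (0.10 log units; within the scatter) stays within the scatter, so the two numbers stand level. Compound 2 `COc1ccc(S(=O)(=O)N2CCc3cccc(NC(=O)Oc4ccccc4)c32)cc1` reads > 10000 nM, which is a limit of the assay and not a number.

Compound 4 `COc1ccc(S(=O)(=O)N2CCc3cccc(NC(=O)c4ccc(C#N)cc4)c32)cc1` follows from compound 3 with one change: cyano in place of hydrogen on an aromatic carbon. This is cyano in place of hydrogen on an aromatic carbon, para to a large group.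

The large steps of an at least 32-fold higher number from compound 1 to compound 2 (1.50 log units; beyond the scatter) and an at least 40-fold lower number from compound 2 to compound 3 (1.60 log units; beyond the scatter) both turn on phenoxy on the carbonyl carbon. Within the data shown here, that is a different place from the one changing here, so they set no size for this step. The step that bears directly is a 1.2-fold lower number from compound 1 to compound 3 (0.10 log units; within the scatter), where a methoxycarbonyl group and hydrogen are exchanged on the same ring place now taken by cyano. It is a single example, and it involves a different group.

On that step, no change beyond the scatter is expected in this assay, in either direction. The expected step is a 1.0-fold higher number from compound 3 to compound 4 (0.02 log units; within the scatter). For compound 4 the estimated value is 260 nM, with an expected range of 90 nM to 800 nM.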

Compound 4, half-maximal inhibitory concentration: 89 nM
Beside the measured number, compound 4's estimate is 2.9-fold (0.47 log units) above it, and the stated range ends above it.
By their numbers in this assay, from the lowest: compound 4; then compounds 3 and 1 (each within the scatter of the next). At a limit, above all of these: compound 2.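

Cyano at this place, para to a large group, gives the first change on the benzoyl ring that lies beyond the scatter in this assay: a 2.8-fold lower number from compound 3 to compound 4 (0.45 log units; beyond the scatter) while the earlier exchange of methoxycarbonyl and hydrogen on the same ring place stayed within it. The two substituents also differ from each other, with a 3.5-fold lower number from compound 1 to compound 4 (0.54 log units; beyond the scatter) and so the ring place responds to which group it carries, and compound 4 now has the lowest number among the compounds shown. For compound 2 the value is a limit and not a number, so an at least 110-fold lower number from compound 2 to compound 4 (2.05 log units; beyond the scatter) gives a bound and no exact size: the limit of > 10000 nM in this assay, at which 1 of the 4 values shown sits.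

From the compounds shown here alone, the series shows only hydrogen, methoxycarbonyl and cyano at this place, so one cyano result gives no trend across substituents, and whether fluorine, an amine or a carboxylic acid would match compound 4 stays open. Also open, going by these compounds, is whether cyano has the same effect on another carbon of this ring or in a series with a different sulfonyl group.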